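The compounds below may be only part of what the source reports. "The series", "measured", "known", "first", "only" and "open" are said of these compounds alone.

Three compounds have numbers so far:

compound 1, `O=C(CSc1nc2c(c(=O)n1-c1ccccc1)SCC2)Nc1ccc(N2CCCCC2)cc1`: 30 nM
compound 2, `COc1ccc(-n2c(SCC(=O)Nc3nc4ccc(C(F)(F)F)cc4s3)nc3c(c2=O)SCC3)cc1`: 100 nM
compound 3, `COc1ccc(-n2nc(C(=O)NCC(=O)Nc3nc4ccc(OC)cc4s3)c3ccccc3c2=O)cc1`: 60 nM

All three were tested in an assay on L cells for inhibition of Protein-serine O-palmitoleoyltransferase porcupine (Mus musculus), read by reporter gene assay, with a stated time of 24 h; a higher number here means that more compound is needed for the effect, a lower number that less compound is needed. Compound 1 gives 30 nM, the lowest number among the three. Compound 3 gives 60 nM, which lies within the usual scatter of the number for compound 1, so these two cannot be told apart. Compound 2 gives 100 nM, and this gap to compound 1 goes beyond the scatter, so more of compound 2 is needed for the same effect.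

Compound 4, `O=C(CSc1nc2c(c(=O)n1-c1ccccc1)SCC2)Nc1ccc(-c2cccnc2)cc1`, keeps the whole core of compound 1 and alters a single group: pyridin-3-yl in place of piperidin-1-yl on an aromatic carbon. Among the compounds with values here, no pair of measured compounds shows what this exchange does, so the expectation rests on compound 1 alone, with wide uncertainty. In this assay only a small step is expected, a 2.0-fold higher number from compound 1 to compound 4 (0.30 log units; within the scatter), at most a modest rise that stays near the edge of the scatter. Compound 4 is therefore estimated at 60 nM, with a range from 15 nM to 250 nM.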

Compound 4, half-maximal effective concentration: 0.45 nM
Beside the measured number, compound 4's estimate is 130-fold (2.12 log units) above it, outside the stated range (below it).
By their numbers in this assay, from the lowest: compound 4; then compounds 1, 3 and 2 (each within the scatter of the next, the first and the last beyond it).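

In this assay, putting pyridin-3-yl in place of piperidin-1-yl on an aromatic carbon, para to a large group, gives a 67-fold lower number from compound 1 to compound 4 (1.82 log units; beyond the scatter), so this position responds strongly to which ring it carries. The earlier compounds shown here could not show this, since no two of them differed in one place. The two groups match in heavy atoms, hydrogen-bond donors, hydrogen-bond acceptors and net charge, and both are six-membered rings with one hetero atom, so the printed difference between them is that one ring is non-aromatic and the other aromatic, although nothing available gives a reason for the size of the step.

The compounds shown leave open whether the ring nitrogen matters at all and whether its place in the ring does, a question that plain phenyl and pyridin-4-yl at the same position would address. They also leave open whether a non-aromatic ring such as morpholin-4-yl behaves like piperidin-1-yl, and whether the same exchange has a similar effect on a different core.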